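A Further Chloro Group on Compound 3

The compounds below may be only part of what the source reports. "The series", "measured", "known", "first", "only" and "open" are said of these compounds alone.

In a functional assay on SW-620 cells (Homo sapiens) for antiproliferative activity, read by MTT assay, with a stated time of 24 h (a higher number here means a weaker inhibitor, a lower number a stronger inhibitor), compound 3, `COc1ccc(C(=O)/C=C/c2cccc(Cl)c2)c2c1C=CC(C)(C)O2`, gives > 10000 nM, which is a limit and not a number. Compound 1, `COc1ccc(C(=O)/C=C/c2cccc(F)c2)c2c1C=CC(C)(C)O2`, gives > 10000 nM, also a limit. Compound 2, `COc1ccc(/C=C/C(=O)c2ccc(OC)c3c2OC(C)(C)C=C3)cn1`, gives > 10000 nM, again a limit. Across the series so far, the picture is the limit of > 10000 nM in this assay, at which 3 of the 3 values shown sit.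

Compound 4, `COc1ccc(C(=O)/C=C/c2ccc(Cl)c(Cl)c2)c2c1C=CC(C)(C)O2`, carries one change: chloro in place of hydrogen on an aromatic carbon. In other words, 3-chlorophenyl becomes 3,4-dichlorophenyl.

The closest measured change is a step that the two limits leave unreadable from compound 1 to compound 3, which also concerns a halogen on that aromatic ring. The change a step that the two limits leave unreadable from compound 2 to compound 3 bears on the same group, and neither offers a size to carry over. With nothing readable behind it, no firm direction can be argued, and activity in this assay is expected to remain out of reach. The expected step that the limit leaves unreadable from compound 3 to compound 4 is therefore no step beyond the scatter. Compound 4 is estimated at 12000 nM, with an expected range of 5000 nM to 30000 nM.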

Compound 4, half-maximal inhibitory concentration: 7700 nM
Beside the measured number, compound 4's estimate is 1.6-fold (0.19 log units) above it; the measured number falls inside the stated range.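

In this assay, within the data shown here, the chloro group entering this position, ortho to a chloro group and para to a large group, gives compound 4, the only compound with a value that is a number and not a limit. The step is an at least 1.2-fold lower number from compound 3 to compound 4 (0.11 log units; that floor lies within the scatter), so it shows a possible gain at this position without establishing one. The same holds for an at least 1.2-fold lower number from compound 2 to compound 4 (0.11 log units; that floor lies within the scatter) and for an at least 1.2-fold lower number from compound 1 to compound 4 (0.11 log units; that floor lies within the scatter), and most of the series still rests at one limit: the limit of > 10000 nM in this assay, at which 3 of the 4 values shown sit.

As far as these compounds go, the true size of all three steps stays open, since each has only a floor. Also open, from the compounds shown here alone, is whether an amine or a carboxylic acid in place of this chloro group would lower the number further, or whether this chloro group needs the 3-chloro group already on the ring.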